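The source may report more compounds than this note shows. Statements on the series, on what has been measured and on what is new or still open speak of the compounds shown alone.

Measured compounds:
- compound 1 `Cc1nc(-c2ccccc2F)c(C(=O)N2CCN(c3cc(Cl)cc(Cl)c3)CC2)o1`: 60.2 nM
- compound 2 `Cc1nc(-c2ccc(F)cc2)c(C(=O)N2CCN(c3cc(Cl)cc(Cl)c3)CC2)o1`: 52.1 nM
- compound 3 `Cc1nc(-c2ccccc2)c(C(=O)N2CCN(c3cc(Cl)cc(Cl)c3)CC2)o1`: 41.8 nM

All three were tested in a functional assay on HL-60 cells (Homo sapiens) for inhibition, read by MTT assay, with a stated time of 72 h; on this read-out higher numbers stand for weaker inhibition and lower numbers for stronger inhibition. Compound 1 gives the highest of the three numbers, but its neighbours sit close: the step of a 1.2-fold lower number from compound 1 to compound 2 (0.06 log units; within the scatter) and the step of a 1.4-fold lower number from compound 1 to compound 3 (0.16 log units; within the scatter) are both within the scatter, as is the step of a 1.2-fold lower number from compound 2 to compound 3 (0.10 log units; within the scatter). On these numbers, then, the three compounds cannot be told apart.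

Compound 4 `Cc1nc(-c2ccccc2F)c(C(=O)N2CCN(c3cccc(Cl)c3)CC2)o1` has not yet been measured. It differs from compound 1 in one place: hydrogen in place of chloro on an aromatic carbon

Among the measured compounds shown here, none of the measured steps touches this part of the molecule. All three concern the fluoro on the other aromatic ring, and all three stayed within the scatter, so they give no guide to what removing a chloro from the dichlorophenyl ring will do. With no direct comparison available, the expectation can only rest on the size of the group removed, a single heavy atom. The step of a 2.5-fold higher number from compound 1 to compound 4 (0.40 log units; beyond the scatter) is therefore expected to be modest, and more likely toward a higher number than a lower one. Compound 4 is estimated at 150 nM, with a range from 50 nM to 500 nM.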

Compound 4, half-maximal inhibitory concentration: 39.4 nM
Compound 4: the middle estimate sits 3.8-fold (0.58 log units) above what was measured; measured number below the stated range.
By their numbers in this assay, from the lowest: compounds 4, 3, 2 and 1 (each within the scatter of the next).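

Among the compounds shown here, this change is the first measured one on the 3,5-dichlorophenyl ring, and in this assay the step is a 1.5-fold lower number from compound 1 to compound 4 (0.18 log units; within the scatter). Taking away 1 heavy atom, a chloro, and leaving a hydrogen in its place therefore makes no difference that this measurement can detect, so the 3,5-dichloro pattern is not needed in full for a number in this range, at least when the other ring is 2-fluorophenyl. The earlier steps showed such insensitivity only for the fluoro on the other ring, and nothing measured here explains the result at this position.

All the compounds shown still carry at least one chloro on this ring, so it remains open what happens when the remaining chloro is also replaced by hydrogen, or when a methoxy group or an amine takes its place. This comparison also rests on a single pair of compounds, which leaves open whether the same change gives a similar result on compound 3 or compound 2, where the fluoro is absent or sits elsewhere.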